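Swapping a lactam for an anilino group on a fused core

The source may hold more compounds than are shown below. What is called first, only, known or untested is meant among the compounds shown, and "the series" means these compounds.

Measured compounds:
- Compound 1 `Cc1nccn1-c1cnc(NCc2c(F)ccc3c2CCO3)c2cn[nH]c(=O)c12` gives 2.1 in a physicochemical assay for lipophilicity, using the shake flask method, in phosphate buffer, measured as octanol-water partition, with a stated time of 30 min, at pH 7.4; on this read-out higher numbers stand for higher lipophilicity and lower numbers for lower lipophilicity.
- Compound 2 `O=C1CCCN1c1cnc(NCc2c(F)ccc3c2CCO3)n2cnnc12` gives 1.3 in this assay.

For the measured compounds named here, of the two numbers measured so far, compound 2 stands lowest; compound 1 lies above it by a gap that exceeds the usual scatter of the method.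

The next compound, compound 3 `CN(c1ccccc1)c1cnc(NCc2c(F)ccc3c2CCO3)n2cnnc12`, is built from compound 2 by one change: methyl(phenyl)amino in place of 2-oxopyrrolidin-1-yl on an aromatic carbon. A five-membered non-aromatic ring bearing a carbonyl is exchanged for a six-membered aromatic ring of carbon only, attached through a methyl-bearing nitrogen, with two more heavy atoms in the entering group than in the leaving one.

Going by the values given here, no measured pair shows this exact change, so the expectation rests on the structures alone. The step is expected to be upward and well beyond the scatter, as a number 1.60 log units higher from compound 2 to compound 3 (beyond the scatter). Compound 3 is therefore estimated at 2.9, with a likely range from 2.3 to 3.5.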

Compound 3, distribution coefficient: 3.6
Estimate against measurement, compound 3: 0.70 log units below; measured number above the stated range.
By their numbers in this assay, from the lowest: compound 2; then compound 1; then compound 3.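

At this position, an aromatic carbon of the shared core, the choice of group can shift this assay a long way: methyl(phenyl)amino in place of 2-oxopyrrolidin-1-yl gives a number 2.30 log units higher from compound 2 to compound 3 (beyond the scatter). For the compounds shown here, the two earlier compounds differ in more than one place, so this is the first step that can be read as a single change. Nothing available here explains the size of this step.

The entering group differs from the leaving one in several features at once, so this one step cannot show which feature matters. From the compounds shown here alone, it also remains open whether a dimethylamino group or a morpholine ring at this position would give a number closer to that of compound 2 or of compound 3, and whether the same exchange behaves alike on the core of compound 1.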